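A few compounds are considered here, and "the series" means these few. Any claim that something is new, unique, unknown or untested is made for them only; others in the source may bear on it.

Values measured so far in a physicochemical assay for lipophilicity, at pH 7.4; a higher number here means a more lipophilic compound, a lower number a more polar compound:

- compound 1 `CNC(=O)c1sc(N2CC3CC2(CNC(=O)c2c[nH]c4ncccc24)C3)nc1C(F)(F)F` gives 3.1
- compound 2 `CNC(=O)c1sc(N2CC3CC2(CNC(=O)c2c[nH]c4ncc(C)cc24)C3)nc1C(F)(F)F` gives 3.5

Compound 2 holds the higher of these two numbers, and its gap to compound 1 lies beyond the usual scatter. The next compound to be measured is compound 3 `CNC(=O)c1sc(N2CC3CC2(CNC(=O)c2c[nH]c4ncc(Cl)cc24)C3)nc1C(F)(F)F`, which differs from compound 2 in one place: chloro in place of methyl on an aromatic carbon in short, chloro in place of methyl on an aromatic carbon. No ring, hydrogen-bond donor, hydrogen-bond acceptor or net charge enters or leaves with this swap.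

Within the data shown here, only one measured step bears on it, namely a number 0.40 log units higher from compound 1 to compound 2 (beyond the scatter), where methyl took the place of hydrogen on that same aromatic carbon. Among the measured compounds shown here, no chloro compound has been measured yet, so this guide is indirect. With a number 0.40 log units higher from compound 1 to compound 2 (beyond the scatter) as the only reference, a smaller step is expected here, one that probably stays within the scatter and, if it shows at all, points slightly upward. The estimated change is a number 0.10 log units higher from compound 2 to compound 3 (within the scatter) in this assay, which would leave the two compounds hard to tell apart. For compound 3 the estimate is 3.6, with the measurement expected to fall from 3.3 to 3.9 on this scale.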

Compound 3, distribution coefficient: 4
Beside the measured number, compound 3's estimate is 0.40 log units below it; measured number above the stated range.
By their numbers in this assay, from the lowest: compound 1; then compound 2; then compound 3.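

In this assay the swap of methyl for chloro gives a number 0.50 log units higher from compound 2 to compound 3 (beyond the scatter) and so shows that this position separates two groups of one heavy atom each: the result depends on which group replaces the hydrogen, not only on the replacement itself. Measured against the unsubstituted compound, chloro gives a number 0.90 log units higher from compound 1 to compound 3 (beyond the scatter) and this step is larger than the one for methyl on the same aromatic carbon, which is a number 0.40 log units higher from compound 1 to compound 2 (beyond the scatter) and places the three compounds in a clear order, with compound 1 lowest, compound 2 in the middle and compound 3 highest. Nothing available explains why chloro and methyl part so clearly on this scale.

The compounds shown leave open how a methoxy group, a nitrile or a primary amine on this aromatic carbon would read, and whether any of them would fall below compound 1 or above compound 3. They also leave open whether chloro would bring a step of this size on another carbon of the same ring or on a different core.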